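The source may report more compounds than this note shows. Statements on the series, on what has been measured and on what is new or still open speak of the compounds shown alone.

The shared core of these compounds is a spiro-fused scaffold bearing a phenyl group and an amide-linked aryl substituent, and the compounds differ mainly in the group carried on the acetamide arm. Compound 2 `CCOC(=O)C1CCN(C(=O)CN2CN(c3ccccc3)C3(CCN(C(=O)c4ccc(C5CCCCC5)cc4)CC3)C2=O)CC1` gives a half-maximal inhibitory concentration of 900 nM in an assay on HEK293 cells for displacement of a labelled ligand from NPC1-like intracellular cholesterol transporter 1 (Homo sapiens) (on this read-out higher numbers stand for weaker inhibition and lower numbers for stronger inhibition), the lowest number among those measured. Compound 3 `CC(C)(C)c1ccc(C(=O)N2CCC3(CC2)C(=O)N(CC(=O)N2CCN(S(C)(=O)=O)CC2)CN3c2ccccc2)cc1` gives 19000 nM in this assay, a much higher number than compound 2, and the gap between the two lies well beyond the usual scatter. Compound 1 `CC(C)(C)OC(=O)NCCCCNC(=O)CN1CN(c2ccccc2)C2(CCN(C(=O)c3ccc(C(C)(C)C)cc3)CC2)C1=O` carries a different arm, but in this assay compound 1 stands at "not determined" (no result reported), so no result was reported for it.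

Compound 4 `CS(=O)(=O)NCCNC(=O)CN1CN(c2ccccc2)C2(CCN(C(=O)c3ccc(C4CCCCC4)cc3)CC2)C1=O` is not yet measured. Relative to compound 2, it differs in one place: (2-(methanesulfonamido)ethyl)amino in place of 4-(ethoxycarbonyl)piperidin-1-yl on a carbonyl carbon. The ring-containing group is thus exchanged for an open chain that carries two hydrogen-bond donors, and the sulfonamide that appears here also appears in compound 3, which gave the weakest result. Because compound 3 shows 19000 nM, a move toward higher numbers is expected for compound 4, though smaller than the gap from compound 2 to compound 3. The step from compound 2 to compound 4 is estimated at a 3.3-fold higher number from compound 2 to compound 4 (0.52 log units; beyond the scatter), and compound 4 is expected to give about 3000 nM, within a range from 800 nM to 12000 nM.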

Compound 4, half-maximal inhibitory concentration: 2100 nM
For compound 4 the middle estimate is 1.4-fold (0.15 log units) above the measured one; the range from low to high includes it.
By their numbers in this assay, from the lowest: compound 2; then compound 4; then compound 3.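

Among the compounds shown here, until now no two measured compounds differed in one place only, so the group on this carbonyl carbon could not be judged on its own. In this assay, exchanging 4-(ethoxycarbonyl)piperidin-1-yl for (2-(methanesulfonamido)ethyl)amino gives a 2.3-fold higher number from compound 2 to compound 4 (0.37 log units; beyond the scatter), a modest step for a swap that replaces a six-membered ring with an open chain and brings in hydrogen-bond donors where the leaving group has none. This position therefore accepts two very different groups with only a modest change in the number, although nothing measured here explains why the number rises.

This single exchange changes several things at once, removing the ring and the ester and adding the sulfonamide, so the pair cannot show which of these accounts for the step. A compound with a carboxylic acid in place of the ethoxycarbonyl group on the piperidine ring, or one with a propyl chain in place of the ethyl chain of the (2-(methanesulfonamido)ethyl)amino group, would test single parts of the change.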